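Methyl Added to a Second Core: One Step Repeated

A few compounds are considered here, and "the series" means these few. Any claim that something is new, unique, unknown or untested is made for them only; others in the source may bear on it.

Compound 1 `O=c1c(CSC(=S)N2CCCC2)coc2ccccc12` carries a pyrrolidin-1-yl group on its thiocarbonyl carbon, while compound 3 `O=c1c(CSC(=S)N2CCOCC2)coc2ccccc12` carries a morpholin-4-yl group there instead; the difference between the two cores is morpholin-4-yl in place of pyrrolidin-1-yl on a thiocarbonyl carbon. In a functional assay on MDA-MB-435S cells (Homo sapiens) for antiproliferative activity, read by MTT assay, with a stated time of 72 h (a lower number here means a stronger inhibitor, a higher number a weaker inhibitor), compound 1 gives 3800 nM, and compound 3 gives 3900 nM, giving a 1.0-fold higher number from compound 1 to compound 3 (0.01 log units; within the scatter). Compound 2 `Cc1ccc2c(=O)c(CSC(=S)N3CCCC3)coc2c1` is compound 1 with methyl in place of hydrogen on an aromatic carbon, and in this assay compound 2 gives 1900 nM, a step of a 2.0-fold lower number from compound 1 to compound 2 (0.30 log units; within the scatter). Compound 4 `Cc1ccc2c(=O)c(CSC(=S)N3CCOCC3)coc2c1` has not yet been measured; it is compound 3 with methyl in place of hydrogen on an aromatic carbon, the same change made at the same place on the aromatic ring, now on the core of compound 3. Because the step of a 2.0-fold lower number from compound 1 to compound 2 (0.30 log units; within the scatter) lay within the scatter, a step of similar size is expected for compound 4, a 2.0-fold lower number from compound 3 to compound 4 (0.29 log units; within the scatter), with the reservation that this change has so far been seen only once. On that basis compound 4 is estimated to give 2000 nM in this assay, most likely between 1000 nM and 4200 nM.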

Compound 4, half-maximal inhibitory concentration: 5500 nM
The estimate for compound 4 lay 2.8-fold (0.44 log units) below the measured number, outside the stated range (above it).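

In this assay, methyl in place of hydrogen on the core of compound 3 gives a 1.4-fold higher number from compound 3 to compound 4 (0.15 log units; within the scatter), and morpholin-4-yl in place of pyrrolidin-1-yl on the core of compound 2 gives a 2.9-fold higher number from compound 2 to compound 4 (0.46 log units; beyond the scatter). The methyl change does not carry over unchanged from one core to the other: the same change on two cores in this assay, a 2.0-fold lower number (0.30 log units; within the scatter) from compound 1 to compound 2 and a 1.4-fold higher number (0.15 log units; within the scatter) from compound 3 to compound 4, 2.8-fold (0.45 log units) apart, beyond the scatter of two such steps The morpholin-4-yl change shows the same gap, so the two changes do not simply add up in these four compounds, though this does not show why, or whether the same would happen on any other core: the same change on two cores in this assay, a 1.0-fold higher number (0.01 log units; within the scatter) from compound 1 to compound 3 and a 2.9-fold higher number (0.46 log units; beyond the scatter) from compound 2 to compound 4, 2.8-fold (0.45 log units) apart, beyond the scatter of two such steps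

Still open, going by these compounds, is how an ethyl or methoxy group on the same aromatic carbon would behave on these two cores. Equally open, on these data alone, is whether an open-chain amine such as dimethylamino on the thiocarbonyl carbon would depend on the presence of the methyl in the same way.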